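Oxadiazole aryl variation: chloro to methyl in the series

This account rests on a few compounds, and the source may have more. Where it says the series, first, only, none or still open, it means among the compounds named here.

Of the compounds shown here, three have been measured in a functional assay on HCT-116 cells (Homo sapiens) for inhibition, read by MTT assay, with a stated time of 24 h, tested at 2.5 uM; a lower number here means less inhibition of growth, a higher number more inhibition of growth at the concentration tested. Compound 1 `CS(=O)(=O)c1ccc(-c2cnc3[nH]cc(-c4nnc(-c5ccccc5)o4)c(=O)c3c2)cc1` gives 0.53%. Compound 2 `CS(=O)(=O)c1ccc(-c2cnc3[nH]cc(-c4nnc(-c5ccccn5)o4)c(=O)c3c2)cc1` gives 5.37% in this assay. Compound 3 `CS(=O)(=O)c1ccc(-c2cnc3[nH]cc(-c4nnc(-c5ccc(Cl)cc5)o4)c(=O)c3c2)cc1` gives 2.06% in this assay. The three values lie close together: a number 4.8 percentage points higher from compound 1 to compound 2 (within the scatter), a number 1.5 percentage points higher from compound 1 to compound 3 (within the scatter), and a number 3.3 percentage points lower from compound 2 to compound 3 (within the scatter). On the numbers shown compound 3 sits second highest of three, with compound 1 nearest and compound 2 furthest, both gaps within the scatter.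

Compound 4 `Cc1ccc(-c2nnc(-c3c[nH]c4ncc(-c5ccc(S(C)(=O)=O)cc5)cc4c3=O)o2)cc1` differs from compound 3 in one place: methyl in place of chloro on an aromatic carbon. The step that bears on this most is the earlier change at the same place, from hydrogen to chloro, which gave a number 1.5 percentage points higher from compound 1 to compound 3 (within the scatter); the exchange of the whole aryl group on the oxadiazole gave a number 3.3 percentage points lower from compound 2 to compound 3 (within the scatter). Among the compounds with values here, neither moved the read-out beyond the scatter, and none of the measured compounds shows appreciable growth inhibition at the concentration tested. The step expected in this assay is therefore a number 0.4 percentage points higher from compound 3 to compound 4 (within the scatter), with no direction beyond the scatter. Compound 4 is estimated at 2.5%, within a range from -6% to 11%.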

Compound 4, percent growth inhibition at one concentration: 7.47%
For compound 4 the middle estimate is 5 percentage points below the measured one; low and high end bracket the measured number.
By their numbers in this assay, from the lowest: compounds 1, 3, 2 and 4 (each within the scatter of the next).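

Chloro to methyl at this place on the outer ring, para to a large group, is read as a number 5.4 percentage points higher from compound 3 to compound 4 (within the scatter) in this assay, and the 4-methylphenyl group compares in the same way with the other two aryl groups: a number 6.9 percentage points higher from compound 1 to compound 4 (within the scatter) and a number 2.1 percentage points higher from compound 2 to compound 4 (within the scatter). With a fourth aryl group in hand, every step at this position remains within the scatter, so phenyl, pyridin-2-yl, 4-chlorophenyl and 4-methylphenyl cannot be ranked, and neither the hydrogen, chloro and methyl series nor the change of ring atom separates any compound from the others at the one concentration tested. Nothing available gives a reason for the size of these steps or shows whether they reflect anything beyond repeat variation.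

Still open, going by these compounds, is whether any group at this place moves the read-out beyond the scatter, for instance an aminomethyl group, a carboxylic acid or a longer chain such as butyl in place of methyl. Also open, on these data alone, is whether changes elsewhere on the shared core, such as replacing the methylsulfonyl group with a sulfonamide, would separate compounds that this aryl position leaves together.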